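A few compounds are considered here, and "the series" means these few. Any claim that something is new, unique, unknown or untested is made for them only; others in the source may bear on it.

Measured so far in a toxicity assay on MT4 cells (Homo sapiens) for cytotoxicity, read by MTT assay, with a stated time of 5 days; on this read-out higher numbers stand for lower toxicity in this test and lower numbers for higher toxicity in this test:
compound 1 `Cc1cnc(Nc2ccc(C#N)cc2)nc1Nc1c(F)cc(-c2cccs2)cc1F` gives 8000 nM
compound 2 `Cc1cnc(Nc2ccc(C#N)cc2)nc1Nc1c(F)cc(-c2cncc(C#N)c2)cc1F` gives 50000 nM
compound 3 `Cc1csc(-c2cc(C)c(Nc3ccnc(Nc4ccc(C#N)cc4)n3)c(C)c2)c1` gives 34000 nM

Compound 3 lies within the scatter of compound 2, while compound 1 gives a number lower than both and beyond the scatter from compound 3.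

The next compound is compound 4 `COc1ncc(-c2cc(C)c(Nc3ccnc(Nc4ccc(C#N)cc4)n3)c(C)c2)cn1`, which carries 2-methoxypyrimidin-5-yl in place of 4-methylthiophen-2-yl on an aromatic carbon of the six-membered ring of carbon only, para to a large group (2-methoxypyrimidin-5-yl in place of 4-methylthiophen-2-yl on an aromatic carbon).

Going by the values given here, the one measured step that bears on this has 5-cyanopyridin-3-yl in place of thiophen-2-yl on the core of compound 1, which is not the core of compound 3. That step gave a 6.3-fold higher number from compound 1 to compound 2 (0.80 log units; beyond the scatter) and counts as modest. It is a single pair with a different incoming ring, so it supports direction more than size. Compound 3 also already sits with compound 2 near the top of the numbers seen so far.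

A move in the same direction in this assay is therefore expected, though smaller than that step and possibly not beyond the scatter. The expected change is a 1.6-fold higher number from compound 3 to compound 4 (0.21 log units; within the scatter) in this estimate. For compound 4 the estimated value is 55000 nM with an expected range from 18000 nM to 150000 nM as its bounds.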

Compound 4, half-maximal cytotoxic concentration: 4800 nM
Compound 4: middle estimate off by 11-fold (1.06 log units), on the high side; measured number below the stated range.
By their numbers in this assay, from the lowest: compounds 4 and 1 (each within the scatter of the next); then compounds 3 and 2 (each within the scatter of the next).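

In this assay, 2-methoxypyrimidin-5-yl in place of 4-methylthiophen-2-yl on the aromatic carbon para to a large group gives a 7.1-fold lower number from compound 3 to compound 4 (0.85 log units; beyond the scatter), so this change on the core of compound 3 goes toward higher toxicity in this test. The other step at a ring on this kind of carbon, 5-cyanopyridin-3-yl in place of thiophen-2-yl on the core of compound 1, gives a 6.3-fold higher number from compound 1 to compound 2 (0.80 log units; beyond the scatter) and runs the opposite way, so these two steps show no single direction for exchanging a sulfur-containing five-membered ring for a nitrogen-containing six-membered one. These two steps differ in the core as well as in the groups leaving and entering, and no measurement at hand explains their opposite directions.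

The compounds shown leave open whether the lower number in compound 4 follows the pyrimidine ring or its methoxy group, and whether 5-cyanopyridin-3-yl would give the same direction on the core of compound 3 as on the core of compound 1. A plain pyrimidin-5-yl or a 2-aminopyrimidin-5-yl at this position would bear directly on the first of these questions.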